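Methoxy in Place of Fluoro on a Quinoline Solubility Series

This account rests on a few compounds, and the source may have more. Where it says the series, first, only, none or still open, it means among the compounds named here.

Of the compounds shown here, three have been measured in a physicochemical assay for solubility, with a stated time of 18 h, at pH 7.4; on this read-out higher numbers stand for higher solubility and lower numbers for lower solubility. Compound 1 `c1ccc(Oc2ccc3c(NCCCNCc4ccco4)ccnc3c2)cc1` gives 14500 nM, compound 3 `COc1cccc(Oc2ccc3c(NCCCNCc4cc(F)ccc4OC)ccnc3c2)c1` gives 14500 nM, and compound 2 `Fc1ccc(-c2ccc3c(NCCCNCc4ccco4)ccnc3c2)cc1` gives 32000 nM, the highest of the three. Going by the values given here, the only single-point step among them is a 2.2-fold higher number from compound 1 to compound 2 (0.34 log units; beyond the scatter). Compound 4 `COc1ccc(-c2ccc3c(NCCCNCc4ccco4)ccnc3c2)cc1` differs from compound 2 by methoxy in place of fluoro on an aromatic carbon. Among the compounds with values here, no measured step bears directly on this change: compound 3 carries methoxy groups but differs from the others in several places, so its value offers no clean comparison. Within the data shown here, the one step seen, from compound 1 to compound 2, concerns a different exchange and was modest. Compound 4 is therefore expected to sit close to compound 2, with a step of a 1.3-fold lower number from compound 2 to compound 4 (0.11 log units; within the scatter) in this assay that need not exceed the scatter. Compound 4 is estimated at 25000 nM, between 9000 nM and 65000 nM.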

Compound 4, solubility: 32000 nM
Compound 4: middle estimate off by 1.3-fold (0.11 log units), on the low side, and the stated range covers the measured number.
By their numbers in this assay, from the lowest: compounds 1 and 3 (each within the scatter of the next); then compounds 2 and 4 (each within the scatter of the next).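

In this assay, going by these compounds alone, the exchange on the aromatic carbon para to a large group gives no change at the digits printed from compound 2 to compound 4 (within the scatter) and so provides the first direct reading of methoxy in place of fluoro. Replacing phenoxy with 4-methoxyphenyl gives a 2.2-fold higher number from compound 1 to compound 4 (0.34 log units; beyond the scatter) and matches a 2.2-fold higher number from compound 1 to compound 2 (0.34 log units; beyond the scatter) in size, so 4-fluorophenyl and 4-methoxyphenyl read alike against phenoxy. Nothing available explains this result. Still open, as far as these compounds go, is whether an amine, a carboxylic acid or a longer chain in the same place would also leave this assay unmoved.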